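Swapping bromo for chloro on the fused ring of compound 3

The compounds below may be only part of what the source reports. "The series", "measured", "known", "first", "only" and "open" are said of these compounds alone.

Three compounds share one core. Compound 1 `COc1ccc(C2CC(c3ccccc3)=NN2C2=NC(=O)/C(=C3\C(=O)Nc4ccc(Br)cc43)S2)cc1` gives 660 nM in a functional assay on cells (Cancer cell lines, Homo sapiens) for cytotoxicity, read by sulforhodamine B assay, with a stated time of 48 h; a lower number here means a stronger inhibitor of growth, a higher number a weaker inhibitor of growth. Compound 2 `CN(C)c1ccc(C2CC(c3ccccc3)=NN2C2=NC(=O)/C(=C3\C(=O)Nc4ccccc43)S2)cc1` gives 34000 nM in this assay. Compound 3 `CN(C)c1ccc(C2CC(c3ccccc3)=NN2C2=NC(=O)/C(=C3\C(=O)Nc4ccc(Br)cc43)S2)cc1` gives 720 nM in this assay, which places compound 3 second highest of the three numbers: the step of a 1.1-fold higher number from compound 1 to compound 3 (0.04 log units; within the scatter) is a small one, while the step of a 47-fold lower number from compound 2 to compound 3 (1.67 log units; beyond the scatter) is a large one.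

Compound 4 `CN(C)c1ccc(C2CC(c3ccccc3)=NN2C2=NC(=O)/C(=C3\C(=O)Nc4ccc(Cl)cc43)S2)cc1` differs from compound 3 by one exchange: chloro in place of bromo on an aromatic carbon. Going by the values given here, no measured pair here swaps bromo for chloro, so the only step that bears on this exchange is a 47-fold lower number from compound 2 to compound 3 (1.67 log units; beyond the scatter), which shows how much the bromo substituent on that ring carbon contributes against hydrogen. Chloro is a halogen as well, so compound 4 is expected to keep most of that gain, with a modest upward drift estimated at a 1.7-fold higher number from compound 3 to compound 4 (0.22 log units; within the scatter) in this assay, a shift that could well sit within the scatter. Compound 4 is therefore estimated at 1200 nM, with a range from 400 nM to 4000 nM.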

Compound 4, concentration for total growth inhibition: 690 nM
Compound 4: the middle estimate sits 1.7-fold (0.24 log units) above what was measured; low and high end bracket the measured number.
By their numbers in this assay, from the lowest: compounds 1, 4 and 3 (each within the scatter of the next); then compound 2.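

In this assay, exchanging bromo for chloro on this aromatic carbon gives a 1.0-fold lower number from compound 3 to compound 4 (0.02 log units; within the scatter), so the two halogens cannot be told apart at this position. Chloro in place of hydrogen gives a 49-fold lower number from compound 2 to compound 4 (1.69 log units; beyond the scatter), which is also a large step, so in these dimethylamino compounds the gain seen earlier is not confined to bromo but appears with either halogen. Nothing available explains why a halogen on this ring carbon matters.

As far as these compounds go, whether the gain requires a halogen at all remains open, and fluoro, iodo, methyl or a nitrile on the same carbon would help to settle that. It also remains open whether chloro would match bromo in the methoxy compound, where only bromo is shown.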